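Notes on a chloro addition to the benzylsulfanyl group

A few compounds are considered here, and "the series" means these few. Any claim that something is new, unique, unknown or untested is made for them only; others in the source may bear on it.

Measured so far:
compound 1 `COc1ccc(C2N=C(SCc3cccc(Cl)c3)NC(C)=C2C(=O)Nc2ccc(Br)cc2)cc1` — 32.8%
compound 2 `CC1=C(C(=O)Nc2ccc([N+](=O)[O-])cc2)C(c2ccc(Br)cc2)N=C(SCc2ccccc2)N1` — 27.2%

In a functional assay on the whole organism (artery, strain albino) with Rattus norvegicus as the target, with a stated time of 600 min, at a dose of 10 mg/kg by the oral route (on this read-out lower numbers stand for less inhibition and higher numbers for more inhibition at the one dose given (going by the name of the read-out)), compound 1 gives 32.8% and compound 2 gives 27.2%. Compound 2 has the lower of the two numbers, but its gap to compound 1 lies within the usual scatter, so the two values show no real difference. Compound 1 and compound 2 differ from each other in more than one place, so the pair says nothing about any single change.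

Compound 3 `CC1=C(C(=O)Nc2ccc([N+](=O)[O-])cc2)C(c2ccc(Br)cc2)N=C(SCc2ccccc2Cl)N1` is the next compound. It differs from compound 2 by chloro in place of hydrogen on an aromatic carbon. Among the measured compounds shown here, no step between measured compounds isolates a change of this kind, so the expectation rests on the two values at hand. Because compound 2 gives 27.2% in this assay and compound 1, which also carries a chloro on its benzyl group, stands within the scatter of that, the expected step of a number 3.8 percentage points higher from compound 2 to compound 3 (within the scatter) is one not beyond the scatter, with no direction claimed. Compound 3 is therefore estimated at 31%, within a range from 18% to 45%.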

Compound 3, a percentage reported as inhibition, in the whole organism at one dose (the size of the read-out at that dose, not a potency): 9.7%
Beside the measured number, compound 3's estimate is 21.3 percentage points above it, and the stated range ends above it.
By their numbers in this assay, from the lowest: compound 3; then compounds 2 and 1 (each within the scatter of the next).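

In this assay, among the compounds shown here, the change from benzylsulfanyl to (2-chlorobenzyl)sulfanyl gives a number 17.5 percentage points lower from compound 2 to compound 3 (beyond the scatter) and is the first single-place step, so this read-out does respond to one chloro in place of hydrogen on an aromatic carbon ortho to a large group. For the compounds shown here, compound 1 also carries a chloro on its benzyl group, but it differs from compound 2 in more than one place, so its value cannot show what a chloro does there and only this one step speaks to the change. Nothing at hand bears on why the number falls with this change.

Going by these compounds, it remains open whether the step belongs to chloro itself or to any group at this carbon, a question that an amine or a carboxylic acid in the same place would help to settle. On these data alone, it is also open whether the same step would appear with the other groups of compound 1 around the shared core, or whether it holds only with those of compound 2.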